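This account rests on a few compounds, and the source may have more. Where it says the series, first, only, none or still open, it means among the compounds named here.

Measured so far in a functional assay on DWD cells (Homo sapiens) for inhibition, read by sulforhodamine B assay; a lower number here means a stronger inhibitor of growth, a higher number a weaker inhibitor of growth:
- compound 1 `Cc1ccc2[nH]c(-c3ccc(-c4ccc(-c5cccc(Cl)c5)cc4)cc3)nc2c1`: 2510 nM
- compound 2 `COc1cc(-c2ccc(-c3ccc(-c4nc5ccccc5[nH]4)cc3)cc2)cc(OC)c1OC`: 8010 nM
- compound 3 `COc1ccc(-c2ccc(-c3ccc(-c4nc5c(O)cccc5[nH]4)cc3)cc2)cc1`: 6400 nM

Compound 1 has the lowest number of the three, and its gaps to both compound 3 and compound 2 lie beyond the scatter. The next compound is compound 4 `Cc1ccc2[nH]c(-c3ccc(-c4ccc(-c5ccc(O)cc5)cc4)cc3)nc2c1`, in which 4-hydroxyphenyl takes the place of 3-chlorophenyl on an aromatic carbon, para to a large group: 4-hydroxyphenyl in place of 3-chlorophenyl on an aromatic carbon.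

Among the compounds with values here, no two measured compounds differ in one place only, so no direct step is available as a guide in this assay. The only indication is indirect. Compound 2 at 8010 nM and compound 3 at 6400 nM carry methoxy groups and no chlorine, but each also differs from compound 1 elsewhere. A moderate rise in the number, towards weaker growth inhibition, is therefore expected, with an estimated step of a 2.2-fold higher number from compound 1 to compound 4 (0.34 log units; beyond the scatter). For compound 4 the estimated value is 5500 nM, with an expected range of 2000 nM to 13000 nM.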

Compound 4, concentration for 50% growth inhibition: 21200 nM
Beside the measured number, compound 4's estimate is 3.9-fold (0.59 log units) below it; the whole stated range lies below it.
By their numbers in this assay, from the lowest: compound 1; then compounds 3 and 2 (each within the scatter of the next); then compound 4.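

In this assay, within the data shown here, the exchange of 3-chlorophenyl for 4-hydroxyphenyl gives an 8.4-fold higher number from compound 1 to compound 4 (0.93 log units; beyond the scatter) and is the first single-place comparison, showing that this aromatic carbon, para to a large group, does not accept every substituted phenyl equally. The change in growth inhibition arises with 7 heavy atoms in both the leaving and the entering group, while 1 hydrogen-bond donor and 1 hydrogen-bond acceptor enter with the 4-hydroxyphenyl. No measurement at hand accounts for this step.

The compounds shown leave open whether the step follows from the loss of chlorine, the arrival of hydroxyl, or the different place of the substituent on the phenyl ring. A pair built on 4-chlorophenyl and 3-hydroxyphenyl, or on plain phenyl, would separate these readings on the core of compound 1.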